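Swapping an Isobutyl Arm for an Azepane Ring

This account rests on a few compounds, and the source may have more. Where it says the series, first, only, none or still open, it means among the compounds named here.

Of the compounds shown here, three sharing one core have been measured in a functional assay on cells for antagonist activity at prostaglandin E2 receptor EP1 subtype (Rattus norvegicus), read by fluorescence and calcium flux, with a stated time of 60 s; on this read-out lower numbers stand for stronger inhibition and higher numbers for weaker inhibition. Compound 1 `O=C(O)c1cccc(Cc2c(-c3ccc(Cl)cc3)nn3cc(Cl)ccc23)n1` gives 1100 nM; compound 2 `COc1ccc(-c2nn3cc(Cl)ccc3c2Cc2cccc(C(=O)O)n2)cc1` gives 5400 nM; compound 3 `CC(C)Cc1nn2cc(Cl)ccc2c1Cc1cccc(C(=O)O)n1` gives 200 nM, the lowest number of the three. Both steps toward it, a 5.5-fold lower number from compound 1 to compound 3 (0.74 log units; beyond the scatter) and a 27-fold lower number from compound 2 to compound 3 (1.43 log units; beyond the scatter), show that trading an aromatic substituent for a small branched chain went with stronger inhibition. Compound 4 `O=C(O)c1cccc(Cc2c(N3CCCCCC3)nn3cc(Cl)ccc23)n1` differs from compound 3 by azepan-1-yl in place of isobutyl on an aromatic carbon. For the measured compounds named here, no measured pair tests a saturated nitrogen ring at this position, so the two earlier steps bear only loosely on it. Compound 4 is expected to land near compound 3, with an estimated step of a 2.0-fold higher number from compound 3 to compound 4 (0.30 log units; within the scatter). The estimate for compound 4 is 400 nM, spanning 100 nM to 1600 nM.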

Compound 4, half-maximal inhibitory concentration: 1400 nM
For compound 4 the middle estimate is 3.5-fold (0.54 log units) below the measured one; the measured number falls inside the stated range.
By their numbers in this assay, from the lowest: compound 3; then compounds 1 and 4 (each within the scatter of the next); then compound 2.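

Azepan-1-yl does not carry over the stronger inhibition seen with isobutyl at this position, giving a 7.0-fold higher number from compound 3 to compound 4 (0.85 log units; beyond the scatter). Compared with the aromatic groups, the outcome depends on which one it replaces: a 1.3-fold higher number from compound 1 to compound 4 (0.10 log units; within the scatter) for 4-chlorophenyl, but a 3.9-fold lower number from compound 2 to compound 4 (0.59 log units; beyond the scatter) for 4-methoxyphenyl. Nothing available explains the cause of these steps.

Still open, going by these compounds, is whether the loss follows from the ring nitrogen or from the seven-membered ring. Piperidine or pyrrolidine in this place, or a chain such as cyclohexylmethyl, would help separate the two.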